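The source may report more compounds than this note shows. Statements on the series, on what has been measured and on what is new or still open speak of the compounds shown alone.

In an ADME assay on HEK293 cells (Homo sapiens) for cytotoxicity, read by MTT assay, with a stated time of 72 h (a lower number here means a stronger inhibitor, a higher number a weaker inhibitor), compound 1 `COc1ccc(C2=C(c3cc(OC)c(OC)c(OC)c3)C(=O)CC2O[SiH2]C(C)(C)C)cc1` reads > 100 ug/mL, which is a limit of the assay and not a number. Compound 2 `COc1ccc(C2=C(c3cc(OC)c(OC)c(OC)c3)C(=O)CC2O)cc1` gives 10 ug/mL. Among the measured compounds shown here, the one measured step, an at least 10-fold lower number from compound 1 to compound 2 (1.00 log units; beyond the scatter), lies beyond the scatter and put a hydrogen atom in place of a group on oxygen. Compound 3 `COc1cc(C2=C(c3cc(C)c(OC)c(C)c3)C(O[SiH2]C(C)(C)C)CC2=O)cc(OC)c1OC` keeps that group but has 4-methoxy-3,5-dimethylphenyl in place of 4-methoxyphenyl on a double-bonded ring carbon. For the measured compounds named here, no measured step touches that place, so no change beyond the scatter is expected in this assay. The expected step is a number no higher from compound 1 to compound 3 (the limit leaves the size open). Compound 3 is estimated at 100 ug/mL, with an expected range of 40 ug/mL to 250 ug/mL.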

Compound 3, half-maximal inhibitory concentration: 29 ug/mL
Compound 3: middle estimate off by 3.4-fold (0.54 log units), on the high side; measured number below the stated range.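

In this assay, 4-methoxy-3,5-dimethylphenyl in place of 4-methoxyphenyl on a double-bonded ring carbon gave an at least 3.4-fold lower number from compound 1 to compound 3 (0.53 log units; beyond the scatter), with the group on oxygen kept. Among the compounds shown here, this shows for the first time that this place, and not only that oxygen, bears on the read-out. As far as these compounds go, compound 1 reads > 100 ug/mL, which is a limit and not a number, so the full size of this step stays open: the limit of > 100 ug/mL in this assay, at which 1 of the 3 values shown sits.

From the compounds shown here alone, whether the same change would act alike in compound 2, with its hydrogen atom on that oxygen, remains open. So does the outcome of an amine or a carboxylic acid in place of 4-methoxy-3,5-dimethylphenyl.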